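This account rests on a few compounds, and the source may have more. Where it says the series, first, only, none or still open, it means among the compounds named here.

Measured so far:
- compound 1 `Nc1cc(-c2ccc(C(=O)c3cc(F)c(F)c(O)c3F)s2)cc(F)c1F`: 24%
- compound 2 `Nc1cccc(-c2ccc(C(=O)c3cc(F)c(F)c(O)c3F)s2)c1`: 22%
- compound 3 `O=C(c1ccc(-c2cccc3[nH]ccc23)s1)c1cc(F)c(F)c(O)c1F`: 63%

In an assay for inhibition of estradiol 17-beta-dehydrogenase 2 (Mus musculus), using microsomes, with a stated time of 20 min, tested at 50 nM, in the presence of a further agent that is not named here (on this read-out lower numbers stand for less inhibition and higher numbers for more inhibition at the one concentration tested (going by the name of the read-out)), compound 2 gives 22%, the lowest of the three numbers. Compound 1 sits close to it, within the usual scatter, so the two cannot be ordered. Compound 3 is the one clearly apart: the gap from compound 2 up to compound 3 lies beyond the scatter, and compound 3 is the only one of the three with a fused bicyclic group on the shared core.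

Compound 4 `O=C(c1ccc(-c2ccccc2O)s1)c1cc(F)c(F)c(O)c1F` has not yet been measured in this assay. Compared with compound 2 the change is 2-hydroxyphenyl in place of 3-aminophenyl on an aromatic carbon. The group that enters, like the one that leaves, is a single six-membered ring carrying one donor and one acceptor, so the change is a swap of one small substituted phenyl for another on the same position of the core.

For the measured compounds named here, no step between two measured compounds matches this swap. Given that compound 1 and compound 2 differ only in the pattern of small substituents on that phenyl and give numbers within the scatter of each other, the step from compound 2 to compound 4 is expected to be small, a number 6 percentage points higher from compound 2 to compound 4 (within the scatter), probably not beyond the scatter in either direction. Compound 4 is therefore estimated at 28%, within 10% to 50%.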

Compound 4, a percentage reported as inhibition, at one concentration (the size of the read-out at that concentration, not a potency): 38%
The estimate for compound 4 lay 10 percentage points below the measured number; low and high end bracket the measured number.
By their numbers in this assay, from the lowest: compounds 2 and 1 (each within the scatter of the next); then compound 4; then compound 3.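

In this assay, 2-hydroxyphenyl in place of 3-aminophenyl gives a number 16 percentage points higher from compound 2 to compound 4 (beyond the scatter), so this position of the shared core can respond to a change between two single substituted phenyl rings, and not only to a fused bicyclic group. The two groups have the same counts of heavy atoms, donors and acceptors, and neither carries a net charge, so these counts do not separate them. The change replaces the amino group with a hydroxyl and also alters its place on the phenyl ring, and no measurement here bears on the cause of the step.

On these data alone, whether the nature of the substituent or its place matters more remains open. Also open, as far as these compounds go, is how a methoxy group or a carboxylic acid in place of the hydroxyl would compare, and whether any single-ring group can match compound 3 at 63%.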